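The compounds below may be only part of what the source reports. "The series", "measured", "known", "first", "only" and "open" are said of these compounds alone.

In a functional assay on PC-3M cells (Homo sapiens) for antiproliferative activity, read by microscopy, with a stated time of 24 h (on this read-out lower numbers stand for stronger inhibition and higher numbers for weaker inhibition), compound 1 `COc1ccc(-c2c(-c3ccc(OC)cc3)n(Cc3ccccc3)c3ncn([C@H]4CC[C@H](OC)CC4)c(=N)c23)cc1` gives no number, only a limit of the assay, > 20000 nM. Compound 2 `COc1ccc(Cn2c(-c3ccccc3)c(-c3ccccc3)c3c(=N)n(CC4CCCO4)cnc32)cc1` gives 8630 nM; 8510 nM (2 entries), and compound 3 `N=c1c2c(-c3ccccc3)c(-c3ccccc3)n(CC3CC3)c2ncn1C1CCOCC1` gives 830 nM; 832 nM (2 entries). Compound 4 `COc1ccc(-c2c(-c3ccc(OC)cc3)n(Cc3ccccc3)c3ncn(CC4CCOC4)c(=N)c23)cc1` departs from compound 1 at one place, (oxolan-3-yl)methyl in place of 4-methoxycyclohexyl on an aromatic nitrogen. Within the data shown here, no measured pair isolates this change, so only a modest gain toward stronger inhibition is expected in this assay. That expectation rests on compound 2, at 8630 nM; 8510 nM (2 entries), which also carries a five-membered non-aromatic ring with 1 hetero atom. The expected change is an at least 1.8-fold lower number from compound 1 to compound 4 (0.25 log units; that floor lies within the scatter). For compound 4 the estimated value is 11000 nM, within an expected range of 4000 nM to 20000 nM.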

Compound 4, half-maximal inhibitory concentration: > 20000 nM
Compound 4 ended at the assay's limit; the forecaster's own chance of this, stated with the estimate: 30%; middle value at least 1.8-fold (0.25 log units) away from the limit.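

In this assay, among these compounds, compound 1 and compound 4 each give only a limit, not a number, so no step between them can be read. Going by these compounds, whether (oxolan-3-yl)methyl in place of 4-methoxycyclohexyl changes inhibition on this core stays open.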